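The compounds below may be only part of what the source reports. "The series", "measured", "known", "first", "only" and "open" are said of these compounds alone.

Measured in a functional assay on HOS cells (Homo sapiens) for inhibition, read by MTT assay, with a stated time of 72 h; a higher number here means a weaker inhibitor, a lower number a stronger inhibitor:

Compound 1, `O=C(O)CCC(=O)OCCCCCCSc1ccc([N+](=O)[O-])c2nonc12`: 8740 nM
Compound 2, `Cc1ccc(NC(=O)CCC(=O)OCCCCCCSc2ccc([N+](=O)[O-])c3nonc23)cc1`: 3340 nM
Compound 3, `O=C(CCC(=O)OCCCCCCSc1ccc([N+](=O)[O-])c2nonc12)Nc1ccc(F)c(Cl)c1`: 2800 nM

Compound 1 has the highest of these three numbers, so it is the weakest inhibitor here, and its steps to both other compounds lie beyond the scatter. Compound 4, `O=C(CCC(=O)N1CCCCC1)OCCCCCCSc1ccc([N+](=O)[O-])c2nonc12`, is not yet measured. It differs from compound 1 in one place: piperidin-1-yl in place of hydroxy on a carbonyl carbon. Two measured steps swap the same hydroxy on the same carbonyl carbon for an amino-type group: a 2.6-fold lower number from compound 1 to compound 2 (0.42 log units; beyond the scatter) and a 3.1-fold lower number from compound 1 to compound 3 (0.49 log units; beyond the scatter). Both are modest improvements, and the two amides sit close together (a 1.2-fold lower number from compound 2 to compound 3 (0.08 log units; within the scatter)). Piperidin-1-yl brings no hydrogen-bond donor, unlike those arylamino groups, so this step is less certain, yet a modest lowering is expected: a 2.3-fold lower number from compound 1 to compound 4 (0.36 log units; beyond the scatter). Compound 4 is therefore estimated at 3800 nM, between 1600 nM and 9000 nM.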

Compound 4, half-maximal inhibitory concentration: 1790 nM
For compound 4 the middle estimate is 2.1-fold (0.33 log units) above the measured one; the measured number falls inside the stated range.
By their numbers in this assay, from the lowest: compounds 4, 3 and 2 (each within the scatter of the next); then compound 1.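

Piperidin-1-yl on this carbonyl carbon gives a lower number (a 4.9-fold lower number from compound 1 to compound 4 (0.69 log units; beyond the scatter)) while carrying no hydrogen-bond donor, so the lowering from the hydroxy compound does not require the amide hydrogen present in compounds 2 and 3. The non-aromatic ring cannot be separated from either arylamino group, with both steps (a 1.6-fold lower number from compound 3 to compound 4 (0.19 log units; within the scatter); a 1.9-fold lower number from compound 2 to compound 4 (0.27 log units; within the scatter)) inside the scatter. No supporting measurement accounts for these results.

Still open, from the compounds shown here alone, is whether a morpholine ring or a simple dimethylamino group would give similar numbers here. Going by these compounds, the effect of a longer chain also remains unknown.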